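Chloro pyrazolyl swap at the clearance limit

The source may report more compounds than this note shows. Statements on the series, on what has been measured and on what is new or still open speak of the compounds shown alone.

Measured in an ADME assay on microsomes from liver (Homo sapiens) for metabolic stability (a higher number here means faster removal of the compound, a lower number slower removal), so far:
- Compound 1 `O=C(O)CCNC(=O)c1ccc(C(Oc2ccc(-n3cc(C(F)(F)F)cn3)cc2)C2CC2)cc1` gives < 8 mL/min/kg as a limit
- Compound 2 `CCCC(Oc1ccc(-n2cc(C(F)(F)F)c(C)n2)cc1)c1ccc(C(=O)NCCC(=O)O)cc1` gives < 10 mL/min/kg as a limit

Compound 2 stands only at a limit (< 10 mL/min/kg), with no number behind it. Compound 3 `CCCC(Oc1ccc(-n2cc(Cl)cn2)cc1)c1ccc(C(=O)NCCC(=O)O)cc1` carries 4-chloro-1H-pyrazol-1-yl in place of 3-methyl-4-(trifluoromethyl)-1H-pyrazol-1-yl on an aromatic carbon, para to a large group 4-chloro-1H-pyrazol-1-yl in place of 3-methyl-4-(trifluoromethyl)-1H-pyrazol-1-yl on an aromatic carbon on the shared core. Going by the values given here, no measured step covers this change. The expected step is a step that the limit leaves unreadable from compound 2 to compound 3 and no move beyond the scatter is expected in this assay here. Compound 3 is estimated at 8 mL/min/kg (expected range 4 mL/min/kg to 16 mL/min/kg), though a limit may again be all that is reported.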

Compound 3, clearance: 10 mL/min/kg
Estimate against measurement, compound 3: 1.3-fold (0.10 log units) below; the measured number falls inside the stated range.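

In this assay, going by these compounds alone, compound 3 gives the first actual number, 10 mL/min/kg, so 4-chloro-1H-pyrazol-1-yl at this position can be read directly. The earlier compounds shown here gave only limits. Replacing 3-methyl-4-(trifluoromethyl)-1H-pyrazol-1-yl with this group gives a number no lower from compound 2 to compound 3 (the limit leaves the size open). The size of that step cannot be read because of the limit for compound 2: the limit of < 10 mL/min/kg in this assay, at which 1 of the 3 values shown sits.

From the compounds shown here alone, the swap changes the methyl and the trifluoromethyl together, and their separate contributions stay open. Also open, going by these compounds, is how a nitrile in place of the chlorine would read in this assay.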